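Removing the methoxy and methyl from the ring nitrogen aryl

The compounds below may be only part of what the source reports. "The series", "measured", "known", "first", "only" and "open" are said of these compounds alone.

Three compounds of this series have numbers in a functional assay on HOS-TE85 cells (Homo sapiens) for inhibition, read by CCK-8 assay, with a stated time of 72 h; a lower number here means a stronger inhibitor, a higher number a weaker inhibitor. Compound 1 `COc1ccc(C)cc1N1C(=O)CSC1c1cccc(C(=O)NCCCCc2ccccc2)c1` gives 300 nM, the highest of the three. Compound 2 `CCOc1ccccc1N1C(=O)C(C)SC1c1cccc(C(=O)NCCCCc2ccccc2)c1` gives 71.6 nM, a lower number than compound 1 and a gap beyond the scatter, though it also carries an ethoxy and a methyl on the five-membered ring. Compound 3 `COc1ccccc1N1C(=O)CSC1c1cc(C(=O)NCCCCc2ccccc2)cc(C2CC2)c1` gives 23.5 nM, lower again and well beyond the scatter from compound 1, with a cyclopropyl on the central ring. All three carry an alkoxy group on the aryl attached to the amide-type ring nitrogen.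

Compound 4 `O=C(NCCCCc1ccccc1)c1cccc(C2SCC(=O)N2c2ccccc2)c1` has not been measured. Relative to compound 1 the change is phenyl in place of 2-methoxy-5-methylphenyl on an amide-type nitrogen in a ring. Within the data shown here, nothing in the measured set isolates this change, so no step between measured compounds speaks to it directly. Since every measured compound that gives a lower number than compound 1 keeps an alkoxy on that aryl, a step in this assay toward a higher number, modestly beyond the scatter, is expected. For compound 4 an estimated value of 600 nM is expected, within 180 nM to 2000 nM, which means an expected step of a 2.0-fold higher number from compound 1 to compound 4 (0.30 log units; within the scatter).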

Compound 4, half-maximal inhibitory concentration: 15.9 nM
Beside the measured number, compound 4's estimate is 38-fold (1.58 log units) above it, outside the stated range (below it).
By their numbers in this assay, from the lowest: compounds 4 and 3 (each within the scatter of the next); then compound 2; then compound 1.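

In this assay, the 2-methoxy-5-methylphenyl on the amide-type nitrogen in the ring is not needed for a low number: phenyl in its place gives a 19-fold lower number from compound 1 to compound 4 (1.28 log units; beyond the scatter) and this large step lies beyond the scatter. Among these compounds, this is the only step in the set that changes one place alone, and it shows that this position responds strongly to the aryl it carries, with the smaller phenyl giving the lower number here, and that an alkoxy on this aryl is not a condition for a low number, since compound 4 carries none. No supporting data accompany this step to account for its size, so the shift stands as an observation without an explanation.

From the compounds shown here alone, the step takes away the methoxy and the methyl together, so the shares of the two groups cannot be separated, and whether either one alone carries the penalty stays open. Also open, going by these compounds, is how far this position tolerates other groups on the phenyl, such as a fluorine, an amine or a carboxylic acid, and whether the step holds on the cores with a methyl on the five-membered ring or a cyclopropyl on the central ring.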